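Same Atoms, Joined Differently: Estimating Compound 4

The source may hold more compounds than are shown below. What is called first, only, known or untested is meant among the compounds shown, and "the series" means these compounds.

Of the compounds shown here, three built on one shared core have been tested in a functional assay on the whole organism for antagonist activity, with Rattus norvegicus as the target; a lower number here means that less compound is needed, a higher number that more compound is needed for the effect. Compound 2 `c1ccc2c(c1)CC2CCCN1CCN(c2cccc3c2OCCO3)CC1` gives 0.18 mg/kg, the lowest of the three numbers. Compound 1 `Clc1cccc2c1CC2CCCN1CCN(c2cccc3c2OCCO3)CC1` gives 3.09 mg/kg, and the step of a 17-fold lower number from compound 1 to compound 2 (1.23 log units; beyond the scatter) shows how much the number moves when chloro is taken off. Compound 3 `c1ccc2c(c1)CC2CCCCN1CCN(c2cccc3c2OCCO3)CC1` gives 1.43 mg/kg. The step of a 7.9-fold higher number from compound 2 to compound 3 (0.90 log units; beyond the scatter) goes with a change in the group on the saturated chain carbon and nowhere else.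

Compound 4 `c1ccc2c(c1)CC(CCN1CCN(c3cccc4c3OCCO4)CC1)C2` keeps every atom of compound 2 but joins them differently: a group of 9 heavy atoms (9 carbon; one five-membered non-aromatic ring of carbon only, one six-membered aromatic ring of carbon only) in place of a group of 9 heavy atoms (9 carbon; one four-membered non-aromatic ring of carbon only, one six-membered aromatic ring of carbon only), on a saturated chain carbon, two bonds along the chain from an amine nitrogen in a ring. Going by the values given here, no measured step changes the same bonds, so none bears on it directly. The closest guide is a 7.9-fold higher number from compound 2 to compound 3 (0.90 log units; beyond the scatter), where a change in the same region of the molecule moved the number modestly, and a 17-fold lower number from compound 1 to compound 2 (1.23 log units; beyond the scatter) shows this region can matter a great deal. A modest step, most likely toward a higher number, is therefore expected, a 2.5-fold higher number from compound 2 to compound 4 (0.40 log units; beyond the scatter). Compound 4 is estimated to give 0.45 mg/kg, with a range from 0.12 mg/kg to 1.8 mg/kg.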

Compound 4, dose for 50% inhibition: 0.27 mg/kg
For compound 4 the middle estimate is 1.7-fold (0.22 log units) above the measured one; the range from low to high includes it.
By their numbers in this assay, from the lowest: compounds 2 and 4 (each within the scatter of the next); then compound 3; then compound 1.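

In this assay, going by these compounds alone, the step of a 1.5-fold higher number from compound 2 to compound 4 (0.18 log units; within the scatter) is the first change around this saturated chain carbon that stays inside the usual scatter. Swapping the group with the four-membered ring for 2,3-dihydro-1H-inden-2-yl, with the same atoms joined differently, therefore leaves no clear difference in this whole-animal test, unlike the step of a 7.9-fold higher number from compound 2 to compound 3 (0.90 log units; beyond the scatter), which lies beyond the scatter. The data shown offer nothing that explains this result.

Going by these compounds, it remains open whether a chloro group on the six-membered aromatic ring of 2,3-dihydro-1H-inden-2-yl would move the number as much as in the step of a 17-fold lower number from compound 1 to compound 2 (1.23 log units; beyond the scatter). On these data alone, the effect of a longer chain between 2,3-dihydro-1H-inden-2-yl and the amine nitrogen also remains open.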